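Swapping trifluoromethoxy for isopropyl on the aryl ring

The source may report more compounds than this note shows. Statements on the series, on what has been measured and on what is new or still open speak of the compounds shown alone.

Compound 1 `CC(C)(C)Cc1c(-c2cc(F)ccc2F)sc(N)c1C(=O)c1ccc(Cl)cc1`: 3%
Compound 2 `CC(C)(C)Cc1c(-c2c(F)cccc2F)sc(N)c1C(=O)c1ccc(Cl)cc1`: 1%
Compound 3 `CC(C)(C)Cc1c(-c2ccc(OC(F)(F)F)cc2)sc(N)c1C(=O)c1ccc(Cl)cc1`: 1%

All three compounds share one core and were tested in an assay on CHO cells for displacement of a labelled ligand from adenosine receptor A1 (Homo sapiens), read by scintillation counting, tested at 10 uM; a higher number here means more inhibition at the concentration tested (going by the name of the read-out), a lower number less inhibition. Compound 3 gives 1%, which is the same number at the digits shown as compound 2, and compound 1 sits within the scatter of both; none of the three separates from the others. Among the measured compounds shown here, the only step between two measured compounds is a number 2 percentage points lower from compound 1 to compound 2 (within the scatter), a rearrangement of fluorine on the ring attached to the core, and it stays within the scatter.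

Compound 4 `CC(C)c1ccc(-c2sc(N)c(C(=O)c3ccc(Cl)cc3)c2CC(C)(C)C)cc1` differs from compound 3 in one place: isopropyl in place of trifluoromethoxy on an aromatic carbon. This exchange is of another kind than the fluorine step, so that step says little about it directly; what the three numbers do show is that every variation of this ring so far has left inhibition near the bottom of the scale. On that basis the expected step of a number 2 percentage points higher from compound 3 to compound 4 (within the scatter) is none beyond the scatter. Compound 4 is therefore estimated at 3%, with a range from 0% to 15%.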

Compound 4, a percentage reported as inhibition, at one concentration (the size of the read-out at that concentration, not a potency): 1%
Estimate against measurement, compound 4: 2 percentage points above; the measured number falls inside the stated range.
By their numbers in this assay, from the lowest: compounds 2, 3, 4 and 1 (each within the scatter of the next).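

In this assay, isopropyl in place of trifluoromethoxy, on an aromatic carbon para to a large group, gives a flat result (no change at the digits printed from compound 3 to compound 4 (within the scatter)). This extends the picture to a ring with no fluorine at all, since the 4-isopropylphenyl ring also reads alongside both difluorophenyl rings (no change at the digits printed from compound 2 to compound 4 (within the scatter)) (a number 2 percentage points lower from compound 1 to compound 4 (within the scatter)), and all four compounds remain indistinguishable. Nothing measured here offers a reason for these numbers.

As far as these compounds go, whether an amine or a carboxylic acid on this ring, or a longer chain in place of isopropyl, would give a number that separates from these four remains open. Also open, from the compounds shown here alone, is whether changes elsewhere on the shared core would move inhibition more than changes to this ring have.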